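This account rests on a few compounds, and the source may have more. Where it says the series, first, only, none or still open, it means among the compounds named here.

Values from a functional assay on MDA-MB-231 cells (Homo sapiens) for antiproliferative activity, read by sulforhodamine B assay, with a stated time of 48 h (on this read-out higher numbers stand for weaker inhibition and lower numbers for stronger inhibition), follow

- compound 1 `COc1cc(OC)c2sc(-c3ccc(N/C=C\C(=O)c4ccc(OC)c(O)c4)c(C)c3)nc2c1` gives 3100 nM
- compound 2 `COc1cc(OC)c2sc(-c3ccc(N/C=C\C(=O)c4ccc(OC)c(O)c4)cc3)nc2c1` gives 7610 nM

Compound 1 holds the lower number of the two, so it shows the stronger inhibition here. For the measured compounds named here, the only measured step is a 2.5-fold higher number from compound 1 to compound 2 (0.39 log units; beyond the scatter).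

Compound 3 `COc1cc(OC)c2sc(-c3ccc(N/C=C\C(=O)c4ccc(OC)c(F)c4)c(C)c3)nc2c1` has not been measured yet. It keeps everything in compound 1 except one group, with fluoro in place of hydroxy on an aromatic carbon. Put another way, 3-hydroxy-4-methoxyphenyl becomes 3-fluoro-4-methoxyphenyl.

The measured step swaps methyl for hydrogen, not the group at stake here, so it gives no direct guide to this swap. It shows only that, in this one pair, a small edit moved the number modestly. Going by the values given here, no measured pair tests the loss of the hydroxy group, so the direction is a judgement and the range must stay wide. A modest move towards a higher number in this assay is expected, and the estimated step is a 1.8-fold higher number from compound 1 to compound 3 (0.25 log units; within the scatter). For compound 3 the expected value is 5500 nM, with an estimated range of 1800 nM to 17000 nM.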

Compound 3, half-maximal inhibitory concentration: 13300 nM
Compound 3: the middle estimate sits 2.4-fold (0.38 log units) below what was measured; the measured number falls inside the stated range.
By their numbers in this assay, from the lowest: compound 1; then compounds 2 and 3 (each within the scatter of the next).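

For the compounds shown here, replacing hydroxy with fluoro on the 3-hydroxy-4-methoxyphenyl ring gives a 4.3-fold higher number from compound 1 to compound 3 (0.63 log units; beyond the scatter) in this assay and so weakens inhibition, which is the first measured sign that this ring position responds to a change of group. The earlier pair altered only a methyl on the other side of the molecule and said nothing about this hydroxy, whereas this pair shows that, with the rest of compound 1 held fixed, fluoro does not serve as an equal stand-in for it. By the simple count, the hydroxy carries a hydrogen-bond donor and an acceptor and the fluoro carries neither, but no measurement here explains why the number rises with this swap.

An amino group or a plain hydrogen at this position would help show whether the hydroxy itself matters or whether fluoro is simply a poor replacement, and the compounds shown do not settle that. As far as these compounds go, it also remains open whether the same swap would have a similar effect in compound 2, which lacks the methyl.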